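Working notes: from compound 2 to compound 3

The source may report more compounds than this note shows. Statements on the series, on what has been measured and on what is new or still open speak of the compounds shown alone.

Measured in a physicochemical assay for solubility, read by HPLC, in phosphate buffer, at pH 6.5; a higher number here means a more soluble compound, a lower number a less soluble compound
- compound 1 `COC(=O)C1=C(CN2CCC(O)C2)NC(c2nccs2)=NC1(C)c1ccc(F)cc1` gives 503 ug/mL
- compound 2 `COC(=O)C1=C(COC2CCOC2)NC(c2nccs2)=NC1(C)c1ccc(F)cc1` gives 30 ug/mL

Compound 2 holds the lower of the two numbers, with compound 1 well above it. The change to compound 3 `COC(=O)C1=C(COC(C(=O)O)C(F)(F)F)NC(c2nccs2)=NC1(C)c1ccc(F)cc1` puts 1-carboxy-2,2,2-trifluoroethyl in place of oxolan-3-yl on an oxygen on a saturated carbon.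

Among the compounds with values here, one measured step bears on this change (a 17-fold lower number from compound 1 to compound 2 (1.22 log units; beyond the scatter)), and it is large. It also concerns the group carried on the chain, though it swaps a different pair of groups, so its size transfers only loosely. Within the data shown here, no measured compound carries the entering group, and the direction is therefore a judgement from the structural change alone. A step of similar size is expected, upward rather than downward in this assay with wide uncertainty.

The estimated change is a 10-fold higher number from compound 2 to compound 3 (1.00 log units; beyond the scatter) in this series. Compound 3 is expected at 300 ug/mL (estimated range 80 ug/mL to 1000 ug/mL).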

Compound 3, solubility: > 649 ug/mL
Compound 3 gave a limit, no number; the forecaster's own chance of this, stated with the estimate: 10%; middle value at least 2.1-fold (0.33 log units) away from the limit.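

In this assay, compound 3 gives a limit of the assay and not a number: the limit of > 649 ug/mL in this assay, at which 1 of the 3 values shown sits.

On the oxygen on a saturated carbon, 1-carboxy-2,2,2-trifluoroethyl in place of oxolan-3-yl gives an at least 21-fold higher number from compound 2 to compound 3 (1.33 log units; beyond the scatter), so the low reading of compound 2 goes with the oxolan-3-yl group and not with the oxygen link itself, which compound 3 keeps. The comparison with the 3-hydroxypyrrolidin-1-yl group of compound 1 reads an at least 1.2-fold higher number from compound 1 to compound 3 (0.11 log units; that floor lies within the scatter), so an oxygen-linked group can reach at least the level of compound 1, while this floor alone sets no order between the two compounds.

From the compounds shown here alone, how far compound 3 lies beyond its limit stays open, and with it the true size of both steps. Also open, going by these compounds, is how the carboxylic acid and the trifluoromethyl part of the entering group each bear on the reading, a question that a plain carboxymethyl group or a methyl ester on the same oxygen would address.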